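Shortening the amine tether on a shared chromone core

The compounds below may be only part of what the source reports. "The series", "measured", "known", "first", "only" and "open" are said of these compounds alone.

Among the compounds with values here, compound 2 `CN(C)CCCCCCCCCCOc1ccc2oc(-c3ccccc3)cc(=O)c2c1` carries the highest of the two numbers measured so far in an assay on isolated protein (Cavia porcellus) with Sigma non-opioid intracellular receptor 1 (Homo sapiens) as the target, read by radioligand binding (on this read-out higher numbers stand for weaker inhibition and lower numbers for stronger inhibition), where compound 2 gives 341 nM. Its nearest neighbour is compound 1 `CN(C)CCCCCCOc1ccc2oc(-c3ccccc3)cc(=O)c2c1`, and in this assay compound 1 gives 335 nM; the two numbers lie within the scatter of each other, so no order between them can be claimed. Within the data shown here, the only measured step, a 1.0-fold higher number from compound 1 to compound 2 (0.01 log units; within the scatter), shows that lengthening the chain between the dimethylamino group and the aromatic oxygen left the number essentially unchanged.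

Compound 3 `O=c1cc(-c2ccccc2)oc2ccc(OCCCN3CCC(O)CC3)cc12` differs from compound 2 by 4-hydroxypiperidin-1-yl in place of 7-(dimethylamino)heptyl on a saturated chain carbon, three bonds along the chain from an oxygen on an aromatic ring. This change touches both the length of the tether and the kind of amine, and neither part is covered by a measured step; the chain-length step between compound 1 and compound 2 only shows that the tether length, taken alone, did not move the number beyond the scatter. Compound 3 is therefore expected to sit near compound 2, with a step of a 1.5-fold higher number from compound 2 to compound 3 (0.17 log units; within the scatter) that is estimated to stay within or only modestly beyond the scatter. The estimate for compound 3 in this assay is 500 nM, with a range from 120 nM to 2500 nM.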

Compound 3, half-maximal inhibitory concentration: 123 nM
The estimate for compound 3 lay 4.1-fold (0.61 log units) above the measured number; the range from low to high includes it.
By their numbers in this assay, from the lowest: compound 3; then compounds 1 and 2 (each within the scatter of the next).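

In this assay the position turns out to respond to what is placed on it: with 4-hydroxypiperidin-1-yl on a saturated chain carbon, three bonds along the chain from an oxygen on an aromatic ring, the series shows a 2.8-fold lower number from compound 2 to compound 3 (0.44 log units; beyond the scatter) and also a 2.7-fold lower number from compound 1 to compound 3 (0.44 log units; beyond the scatter) as its first steps beyond the scatter, both modest. The earlier comparison, a 1.0-fold higher number from compound 1 to compound 2 (0.01 log units; within the scatter) within the scatter, had shown only that lengthening the chain left the number where it was, so the new change reaches something that chain length alone did not. Nothing at hand explains why the number moved.

The change replaces the chain end with a ring, brings in a hydroxyl group and shortens the tether all at once, so the compounds shown cannot say which of these parts carries the lower number. A plain piperidin-1-yl group without the hydroxyl on the tether of compound 3, and a 4-hydroxypiperidin-1-yl group on the longer chain of compound 2, would each separate one of these parts from the others.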